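Bromine on the shared core: one change tried twice

The source may report more compounds than this note shows. Statements on the series, on what has been measured and on what is new or still open speak of the compounds shown alone.

Compound 1 `Cc1nc2ccccc2c(=O)n1NCc1nnc(/N=C/c2ccc(N(C)C)cc2)s1` is tested in a functional assay on the whole organism (strain albino) with Rattus norvegicus as the target, in the maximal electroshock model, with a stated time of 1 h, at a dose of 30 mg/kg by the intraperitoneal route (on this read-out higher numbers stand for more inhibition at the one dose given (going by the name of the read-out) and lower numbers for less inhibition), where compound 1 gives 50%. Compound 2 `Cc1nc2ccc(Br)cc2c(=O)n1NCc1nnc(/N=C/c2ccc(N(C)C)cc2)s1` differs from it only by the change (bromo in place of hydrogen on an aromatic carbon). In this assay compound 2 gives 50%, and the step of no change at the digits printed from compound 1 to compound 2 (within the scatter) shows that this change left the read-out where it was. Compound 3 `Cc1nc2ccccc2c(=O)n1NCC(=O)NNC(N)=S` carries the same core of compound 1 with a different side chain; the difference between compound 3 and compound 1 is not broken down here. In this assay compound 3 gives 30%, the lowest of the three numbers and beyond the scatter from both of the others. Compound 4 `Cc1nc2ccc(Br)cc2c(=O)n1NCC(=O)NNC(N)=S` has not yet been measured. It stands to compound 3 as compound 2 stands to compound 1, through the same change (bromo in place of hydrogen on an aromatic carbon), made at the same place on the shared core. Because the earlier step of no change at the digits printed from compound 1 to compound 2 (within the scatter) stayed within the scatter, the step of no change at the digits printed from compound 3 to compound 4 (within the scatter) is expected to be small as well. Compound 4 is therefore estimated at 30%. Allowing for the scatter, compound 4 is expected to fall between 10% and 50%.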

Compound 4, a percentage reported as inhibition, in the whole organism at one dose (the size of the read-out at that dose, not a potency): 30%
The estimate for compound 4 equals the measured number at the digits printed, within the range that was stated.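

Putting bromo in place of hydrogen on an aromatic carbon of compound 3 gives no change at the digits printed from compound 3 to compound 4 (within the scatter) in this assay, which matches what the same change did with the other side chain: the same change on two cores in this assay, no change at the digits printed (within the scatter) from compound 1 to compound 2 and no change at the digits printed (within the scatter) from compound 3 to compound 4, 0 percentage points apart, within the scatter of two such steps

Within these two pairs, then, the result for this change carried from one side chain to the other, since neither step moved the read-out beyond the usual scatter. For the compounds shown here, this does not show that bromo is without effect in general, as it rests on only two pairs, one position and one dose, and a percentage at a single dose is not a potency, so a real shift smaller than the scatter would pass unseen.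

The compounds shown leave open whether a different group at this same place, such as chloro, methoxy or an amine, would also give a step within the scatter. They also leave open how bromo would behave on a third side chain, for example one ending in a carboxylic acid.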